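Oxetan-3-yl in place of acetyl on an amine nitrogen

A few compounds are considered here, and "the series" means these few. Any claim that something is new, unique, unknown or untested is made for them only; others in the source may bear on it.

In an ADME assay on microsomes from liver (Homo sapiens) for pharmacokinetics, read by LC-MS, with a stated time of 60 min, tested at 1 uM (a higher number here means faster removal of the compound, a lower number slower removal), compound 1 `O=C(NCc1ccc(S(=O)(=O)c2cc(F)cc(F)c2)cc1)N1Cc2ccncc2C1` gives 8 mL/min/kg, compound 2 `CC(C)n1cc(S(=O)(=O)c2ccc(CNC(=O)N3Cc4ccncc4C3)cc2)cn1` gives 4 mL/min/kg, and compound 3 `CC(=O)N1CCC(S(=O)(=O)c2ccc(CNC(=O)N3Cc4ccncc4C3)cc2)CC1` gives 6 mL/min/kg. These three compounds share a core and differ in the group on the sulfonyl sulfur. Compound 3 stands within the scatter of both others, so the numbers do not separate it from either.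

Compound 4 `O=C(NCc1ccc(S(=O)(=O)C2CCN(C3COC3)CC2)cc1)N1Cc2ccncc2C1` keeps everything in compound 3 except one group, with oxetan-3-yl in place of acetyl on an amine nitrogen in a ring. For the measured compounds named here, no measured step tests this exchange directly. Going by the values given here, the steps that bear on it are exchanges of the whole group on the sulfonyl sulfur: a 1.3-fold lower number from compound 1 to compound 3 (0.12 log units; within the scatter), a 1.5-fold higher number from compound 2 to compound 3 (0.18 log units; within the scatter) and a 2.0-fold lower number from compound 1 to compound 2 (0.30 log units; within the scatter). Each of these stays within the scatter, although the groups exchanged are quite different from one another. Among the compounds with values here, none of the measured compounds carries an oxetan-3-yl, so the data give no direction for the change, and the range has to stay wide. The estimated step is no change at the digits printed from compound 3 to compound 4 (within the scatter), which is expected to stay within the scatter. For compound 4 the expected clearance in this assay is 6 mL/min/kg, with an estimated range from 3 mL/min/kg to 12 mL/min/kg.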

Compound 4, clearance: 10 mL/min/kg
For compound 4 the middle estimate is 1.7-fold (0.22 log units) below the measured one; the measured number falls inside the stated range.
By their numbers in this assay, from the lowest: compounds 2, 3, 1 and 4 (each within the scatter of the next, the first and the last beyond it).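

In this assay the exchange of acetyl for oxetan-3-yl is the only step shown that alters just the substituent on the amine nitrogen in the ring and not the whole group on the sulfonyl sulfur, and a 1.7-fold higher number from compound 3 to compound 4 (0.22 log units; within the scatter) does not separate this change from no effect. Among exchanges of the whole group, a 1.3-fold higher number from compound 1 to compound 4 (0.10 log units; within the scatter) also stays within the scatter, whereas a 2.5-fold higher number from compound 2 to compound 4 (0.40 log units; beyond the scatter) is a modest step and the only one shown that lies beyond it, so 1-(oxetan-3-yl)piperidin-4-yl and 1-isopropyl-1H-pyrazol-4-yl are the one pair of groups on the sulfonyl sulfur that the numbers distinguish. Nothing available explains any of these steps.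

Going by these compounds, it remains open how a methyl, a longer acyl chain such as propanoyl or a group carrying a carboxylic acid on the same amine nitrogen would compare with acetyl and oxetan-3-yl. On these data alone, with a single pair of compounds testing this exchange, it is also open whether oxetan-3-yl in place of acetyl would give a similar step on a different core.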